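Swapping chloro for bromo on compound 3

A few compounds are considered here, and "the series" means these few. Any claim that something is new, unique, unknown or untested is made for them only; others in the source may bear on it.

Compound 1 `O=C(CSc1nncnc1-c1cccc2ccccc12)Nc1ccccc1[N+](=O)[O-]`: 142000 nM
Compound 2 `O=C(CSc1nncnc1-c1cccc2ccccc12)Nc1ccc(Cl)cc1Cl`: 254000 nM
Compound 3 `O=C(CSc1nncnc1-c1cccc2ccccc12)Nc1ccccc1Cl`: 63000 nM

All three values come from an ADME assay on MT4 cells (Homo sapiens) for cytotoxicity, read by MTT assay; a lower number here means that less compound is tolerated, a higher number that more compound is tolerated. Compound 3 stands lowest of the three, and both of its steps from the others lie beyond the scatter. The next compound, compound 4 `O=C(CSc1nncnc1-c1cccc2ccccc12)Nc1ccccc1Br`, differs from compound 3 in one place: bromo in place of chloro on an aromatic carbon. In words, it carries bromo in place of chloro on an aromatic carbon.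

Among the measured compounds shown here, no measured step makes this exchange, so the evidence is indirect. The closest cases are a 2.3-fold lower number from compound 1 to compound 3 (0.35 log units; beyond the scatter), with chloro in place of nitro on an aromatic carbon, and a 4.0-fold lower number from compound 2 to compound 3 (0.61 log units; beyond the scatter), with hydrogen in place of chloro. Both are modest, and each swaps chloro with something other than bromo. The remaining step, a 1.8-fold higher number from compound 1 to compound 2 (0.25 log units; within the scatter), stays within the scatter. These steps give no direction for the exchange of chloro for bromo, so no step beyond the scatter is expected in this assay. The expected change is a 1.1-fold lower number from compound 3 to compound 4 (0.02 log units; within the scatter). For compound 4 the estimated value is 60000 nM, with an expected range of 25000 nM to 150000 nM.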

Compound 4, half-maximal cytotoxic concentration: 87000 nM
For compound 4 the middle estimate is 1.5-fold (0.16 log units) below the measured one, within the range that was stated.
By their numbers in this assay, from the lowest: compounds 3, 4, 1 and 2 (each within the scatter of the next, the first and the last beyond it).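

In this assay, among the compounds shown here, the direct exchange of chloro for bromo, on an aromatic carbon ortho to a large group, gives a step that stays within the scatter (a 1.4-fold higher number from compound 3 to compound 4 (0.14 log units; within the scatter)), so this change does not separate the 2-chlorophenyl and 2-bromophenyl amides in the way that the earlier steps separated compound 3 from compounds 1 and 2. Compound 4 also stays within the scatter of the nitro compound (a 1.6-fold lower number from compound 1 to compound 4 (0.21 log units; within the scatter)), whereas the step from compound 1 to compound 3 lies beyond it, and it remains clearly apart from the 2,4-dichlorophenyl compound (a 2.9-fold lower number from compound 2 to compound 4 (0.47 log units; beyond the scatter)), so only compound 2 stands beyond the scatter of compound 4. The data shown here offer no measurement that could explain these numbers.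

The compounds shown leave open whether a smaller fluoro group, or a methyl or methoxy group, in this same place would also stay within the scatter of compound 3. They also leave open whether a second bromo on the phenyl ring would raise the number as far as the second chloro of compound 2 does.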